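All Three Measured Compounds Sit at the Same Lipophilicity

The source may report more compounds than this note shows. Statements on the series, on what has been measured and on what is new or still open speak of the compounds shown alone.

Compound 1 `CCN(Cc1ccccn1)c1ccc(C(=O)N2CCc3ccc(OS(N)(=O)=O)cc3C2)cc1`: 1.93
Compound 2 `CN(C)CCN(CCN(C)C)c1ccc(C(=O)N2CCc3ccc(OS(N)(=O)=O)cc3C2)cc1`: 1.93
Compound 3 `CN(C)CCCN(Cc1ccccc1)c1ccc(C(=O)N2CCc3ccc(OS(N)(=O)=O)cc3C2)cc1`: 1.93

In a physicochemical assay for lipophilicity (a higher number here means a more lipophilic compound, a lower number a more polar compound), compound 2 gives 1.93. Compound 1 gives 1.93 and compound 3 gives 1.93, so compound 2 stands level with both at the digits shown, and none of the three can be called more or less lipophilic than another.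

Compound 4 `CCN(Cc1ccc(Br)cc1)c1ccc(C(=O)N2CCc3ccc(OS(N)(=O)=O)cc3C2)cc1` carries the change ((4-bromobenzyl)(ethyl)amino in place of bis(2-(dimethylamino)ethyl)amino on an aromatic carbon). Within the data shown here, the one measured step that bears on it is no change at the digits printed from compound 1 to compound 2 (within the scatter), where an ethyl((pyridin-2-yl)methyl)amino group was exchanged for the bis(2-(dimethylamino)ethyl)amino group and nothing moved beyond the scatter. The present change runs the other way, removing that same bis(2-(dimethylamino)ethyl)amino group and putting in a (4-bromobenzyl)(ethyl)amino group with one aromatic ring and a bromine. Since the shared core kept this assay steady across compounds 1, 2 and 3, only a modest upward step is expected for compound 4, a number 0.37 log units higher from compound 2 to compound 4 (beyond the scatter), with the chance of no change at all kept open. The value expected for compound 4 is 2.3, in a range from 1.8 to 2.9.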

Compound 4, partition coefficient: 1.93
Estimate against measurement, compound 4: 0.37 log units above; measured number inside the range.
By their numbers in this assay, from the lowest: compounds 1, 2, 3 and 4 (each within the scatter of the next).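

In this assay the swap to (4-bromobenzyl)(ethyl)amino on an aromatic carbon, para to a large group, gives no change at the digits printed from compound 2 to compound 4 (within the scatter) even though the two groups differ considerably: the group that leaves has no ring and 3 nitrogen, while the group that enters has one six-membered aromatic ring of carbon only, 1 nitrogen and 1 bromine. The narrower exchange of pyridin-2-yl for 4-bromophenyl on a saturated chain carbon gives no change at the digits printed from compound 1 to compound 4 (within the scatter) and thus adds a second case, this time with only the aromatic ring on that chain altered, in which a bromine-bearing group leaves the reading level. No measured evidence is at hand to explain this steadiness.

From the compounds shown here alone, all four compounds read alike, so it remains open whether any group at this position can move the number beyond the scatter, and a carboxylic acid, a primary amine or a longer alkyl chain on the same nitrogen would test that. Going by these compounds, it is equally open whether the same level reading would hold if the shared core itself were changed.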